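This account rests on a few compounds, and the source may have more. Where it says the series, first, only, none or still open, it means among the compounds named here.

Compound 1 `Cc1ccc(/C=C2\S/C(=N\c3csc(-c4ccc(Cl)cc4)c3)NC2=O)cc1`, compound 2 `O=C1N/C(=N/c2csc(-c3ccc(Cl)cc3)c2)S/C1=C\c1ccc(O)cc1`, compound 3 `O=C1N/C(=N/c2csc(-c3ccc(Cl)cc3)c2)S/C1=C\c1ccc2ccccc2c1` and compound 4 `COc1ccc(/C=C2\S/C(=N\c3csc(-c4ccc(Cl)cc4)c3)NC2=O)cc1OC` share one core and differ only in the aromatic group that hangs from the double-bonded chain carbon bound to a double-bonded ring carbon. In a functional assay on MDA-MB-231 cells (Homo sapiens) for cytotoxicity, read by MTT assay, with a stated time of 72 h (a lower number here means a stronger inhibitor, a higher number a weaker inhibitor), compound 1 gives 900 nM, and compound 3 gives 1800 nM. For compound 2 the result in this assay is "not determined" (no result reported). Among the compounds with values here, compound 3 therefore holds the higher of the two numbers that exist, yet the single step that reaches it, a 2.0-fold higher number from compound 1 to compound 3 (0.30 log units; within the scatter), is too small to count as a real change.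

The move from compound 3 to compound 4 is 3,4-dimethoxyphenyl in place of naphthalen-2-yl on a double-bonded chain carbon bound to a double-bonded ring carbon. Within the data shown here, the only measured step that bears on this position is the one from compound 1 to compound 3, and it stayed within the scatter. Among the measured compounds shown here, with that as the sole guide, an exchange of one aromatic group for another at this place is expected to leave this assay about where it is, so the expected step is a 1.2-fold lower number from compound 3 to compound 4 (0.08 log units; within the scatter). On that basis compound 4 is estimated to give 1500 nM in this assay, with a plausible range from 500 nM to 5000 nM.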

Compound 4, half-maximal inhibitory concentration: 1900 nM
For compound 4 the middle estimate is 1.3-fold (0.10 log units) below the measured one, and the stated range covers the measured number.
By their numbers in this assay, from the lowest: compounds 1, 3 and 4 (each within the scatter of the next, the first and the last beyond it).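

Replacing naphthalen-2-yl with 3,4-dimethoxyphenyl swaps 2 six-membered aromatic rings for one and brings in 2 hydrogen-bond acceptors, while the count of 10 heavy atoms stays the same, yet in this assay the result is a 1.1-fold higher number from compound 3 to compound 4 (0.02 log units; within the scatter), so this particular exchange makes no readable difference at this place. Within the data shown here, the other new step, a 2.1-fold higher number from compound 1 to compound 4 (0.32 log units; beyond the scatter), is the first at this position to pass the usual scatter, although only modestly, so 3,4-dimethoxyphenyl and 4-methylphenyl can be told apart here, if barely. No measurement shown here accounts for that small difference.

On these data alone, all the groups with a number at this position are built on an aromatic ring of carbon only, so it remains open how a pyridine ring, a saturated cyclohexyl ring or a longer chain would behave on the double-bonded chain carbon bound to a double-bonded ring carbon. As far as these compounds go, it is equally open whether an amine or a carboxylic acid on the aromatic ring would move the number further than these modest steps, and the rest of the shared core stays fixed throughout, so these compounds say nothing about changes there.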